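The compounds below may be only part of what the source reports. "The series", "measured", "known", "first", "only" and "open" are said of these compounds alone.

Measured compounds in an assay for displacement of a labelled ligand from Sigma non-opioid intracellular receptor 1 (Cavia porcellus), read by scintillation counting, with a stated time of 180 min; a lower number here means a stronger inhibitor, a higher number a weaker inhibitor:

compound 1, `COc1ccc(CN2CCC3(CC2)OC(OC)Cc2c3cnn2-c2ccccc2)cc1`, 1.5 nM
compound 2, `COC1Cc2c(cnn2-c2ccccc2)C2(CCN(CCCc3ccccc3)CC2)O1`, 3.2 nM
compound 3, `CCCCN1CCC2(CC1)OC(OC)Cc1c2cnn1-c1ccccc1`, 8 nM

Compound 3 gives the highest number of the three in this assay: compound 2 is the nearest, with a 2.5-fold higher number from compound 2 to compound 3 (0.40 log units; beyond the scatter), and compound 1 the furthest, with a 5.3-fold higher number from compound 1 to compound 3 (0.73 log units; beyond the scatter). Between the other two the step is a 2.1-fold higher number from compound 1 to compound 2 (0.33 log units; beyond the scatter).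

Compound 4, `COC1Cc2c(cnn2-c2ccccc2)C2(CCN(CC(C)C)CC2)O1`, has not yet been measured. It differs from compound 3 in one place: isopropyl in place of propyl on a saturated chain carbon bound to an amine nitrogen in a ring.

For the measured compounds named here, no measured step changes branching alone; the steps into compound 3, from compound 1 and from compound 2, swap a ring-bearing substituent for an open chain and both read modest. A rearrangement within the same three carbons at this position is a smaller change than either, so in this assay compound 4 is expected to stay near compound 3, with at most a small step in either direction. The estimated step is a 1.3-fold higher number from compound 3 to compound 4 (0.10 log units; within the scatter).

Estimate for compound 4 in this assay: 10 nM, expected range 4 nM to 25 nM.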

Compound 4, inhibition constant: 6.3 nM
The estimate for compound 4 lay 1.6-fold (0.20 log units) above the measured number; the measured number falls inside the stated range.
By their numbers in this assay, from the lowest: compound 1; then compounds 2, 4 and 3 (each within the scatter of the next, the first and the last beyond it).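

In this assay, for the compounds shown here, the first step that changes branching alone stays within the scatter (a 1.3-fold lower number from compound 3 to compound 4 (0.10 log units; within the scatter)), so this position reads the same for the straight and the branched open chain. Replacing phenethyl with the branched chain also stays within the scatter (a 2.0-fold higher number from compound 2 to compound 4 (0.29 log units; within the scatter)), whereas replacing 4-methoxyphenyl remains beyond it (a 4.2-fold higher number from compound 1 to compound 4 (0.62 log units; beyond the scatter)), so among these compounds only compound 1 stands clearly apart from compound 4. Nothing available bears on the reason for these readings.

Still open, going by these compounds, is whether a bulkier branched chain such as neopentyl, or a cyclohexylmethyl group, would keep the number close to that of compound 4. Also open, on these data alone, is whether the separation of compound 1 depends on its methoxy group or would persist with an unsubstituted benzyl group.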